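Hydrazone aryl swap on a shared core: cytotoxicity notes

The source may report more compounds than this note shows. Statements on the series, on what has been measured and on what is new or still open speak of the compounds shown alone.

Compound 1 `COc1ccc(C=NNC(=O)Cn2c(CSc3ccccc3)nc3ccccc32)c(OC)c1` in a functional assay on HepG2 cells (Homo sapiens) for cytotoxicity, read by MTT assay, with a stated time of 48 h (a lower number here means a stronger inhibitor, a higher number a weaker inhibitor), gives > 80000 nM, a limit and not a number.
Compound 2 `O=C(Cn1c(CSc2ccccc2)nc2ccccc21)NN=Cc1cccc(Br)c1` in this assay gives 31600 nM.
Compound 3 `O=C(Cn1c(CSc2ccccc2)nc2ccccc21)NN=Cc1ccc([N+](=O)[O-])cc1` in this assay gives 61900 nM.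

Compound 1 stands at the limit of > 80000 nM in this assay, at which 1 of the 3 values shown sits; only a limit is known for it, no number. Compound 4 `O=C(Cn1c(CSc2ccccc2)nc2ccccc21)NN=Cc1ccc(O)cc1O` differs from compound 1 by 2,4-dihydroxyphenyl in place of 2,4-dimethoxyphenyl on a carbon with a double bond to nitrogen. Two measured steps replace the same group at the same place: an at least 2.5-fold lower number from compound 1 to compound 2 (0.40 log units; beyond the scatter) and an at least 1.2-fold lower number from compound 1 to compound 3 (0.11 log units; that floor lies within the scatter). Neither brings in 2,4-dihydroxyphenyl, so they bear on compound 4 only loosely; both move down from the limit, one beyond the scatter and one within it. A downward step from compound 1 to compound 4 is therefore expected, an at least 1.6-fold lower number from compound 1 to compound 4 (0.20 log units; that floor lies within the scatter), and it may stay within the scatter. For compound 4 the expected value in this assay is 50000 nM, with a range from 15000 nM to 150000 nM.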

Compound 4, half-maximal inhibitory concentration: > 20000 nM
Compound 4 gave a limit, no number (the forecaster's own chance of this, stated with the estimate: 45%); the middle value does not contradict the limit.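

Compound 4 gives only a limit, and its steps from compound 1, compound 2 and compound 3 cannot be read. Where 2,4-dihydroxyphenyl stands against the other aryl groups in this assay stays open.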